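Swapping the piperidin-1-yl group of compound 2

A few compounds are considered here, and "the series" means these few. Any claim that something is new, unique, unknown or untested is made for them only; others in the source may bear on it.

In an ADME assay on Caco-2 cells (Homo sapiens) for permeability, read by HPLC, with a stated time of 2 h (a higher number here means that the compound crosses the layer faster, a lower number that the compound crosses the layer more slowly), compound 2 (`O=[N+]([O-])c1ccc(C2=NOC(c3ccc(N4CCCCC4)cc3)C2)o1`) gives 76.1 nm/s. Compound 1 (`O=C1COCCN1c1ccc(C2CC(c3ccc([N+](=O)[O-])o3)=NO2)cn1`) gives 86.1 nm/s, within the scatter of that number, so these two cannot be ranked. Compound 3 (`CN1CCN(c2ccc(C3CC(c4ccc([N+](=O)[O-])o4)=NO3)cn2)C(=O)C1`) gives 366 nm/s, the highest of the three numbers and beyond the scatter of both others.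

Compound 4 (`O=C1COCCN1c1ccc(C2CC(c3ccc([N+](=O)[O-])o3)=NO2)cc1`) has not yet been measured. It arises from compound 2 by a single exchange, 3-oxomorpholin-4-yl in place of piperidin-1-yl on an aromatic carbon.

Going by the values given here, no measured step makes this exact exchange, so the evidence is indirect. The core of compound 4 differs from that of compound 1, which carries the same 3-oxomorpholin-4-yl and gives 86.1 nm/s. Among the compounds with values here, the only measured step, a 4.3-fold higher number from compound 1 to compound 3 (0.63 log units; beyond the scatter), is modest in size and shows that exchanging a group on an aromatic carbon can move the number beyond the scatter. That step involves different groups, so it widens the expected range without setting a direction.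

In this assay no change beyond the scatter is therefore expected, and the estimate means a 1.2-fold higher number from compound 2 to compound 4 (0.10 log units; within the scatter). For compound 4 the estimated value is 95 nm/s, with an expected range from 35 nm/s to 250 nm/s.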

Compound 4, apparent permeability in the Caco-2 assay: 126 nm/s
The estimate for compound 4 lay 1.3-fold (0.12 log units) below the measured number; the range from low to high includes it.
By their numbers in the Caco-2 assay, from the lowest: compounds 2, 1 and 4 (each within the scatter of the next); then compound 3.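

In the Caco-2 assay, placing 3-oxomorpholin-4-yl instead of piperidin-1-yl on this aromatic carbon, para to a large group, gives a 1.7-fold higher number from compound 2 to compound 4 (0.22 log units; within the scatter), so this exchange does not measurably shift the number. Going by these compounds alone, the one earlier step was made on the core of compound 1 and involved other groups, so it could not show how this position behaves on a six-membered aromatic ring of carbon only. In a physicochemical assay for solubility, with a stated time of 18 h, at pH 7.4 (a lower number here means a less soluble compound, a higher number a more soluble compound), compound 2 gives 1.1 ug/mL and compound 4 gives 25.9 ug/mL. The new pair also shows that an exchange with no clear effect in one measurement can have a large effect in another, as the physicochemical assay separates these same two compounds well beyond the scatter: the measured solubility of compound 2, 1.1 ug/mL, and of compound 4, 25.9 ug/mL, a 24-fold higher number (1.37 log units; beyond the scatter)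

The entering group brings a ring oxygen and a carbonyl together, so the compounds shown cannot say which of the two goes with the higher solubility; a plain morpholin-4-yl group or a 2-oxopiperidin-1-yl group at the same place would pull them apart. Going by these compounds, it also remains open whether 4-methyl-2-oxopiperazin-1-yl, which gave the highest number on the core of compound 1, would do the same on the core of compound 4.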